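Ester to thioester on a branched dienoate chain

The source may hold more compounds than are shown below. What is called first, only, known or untested is meant among the compounds shown, and "the series" means these compounds.

Compound 1 `CCC(C)OC(=O)/C=C(C)/C=C/CC(C)CCCC(C)C`: 7.69
Compound 2 `CC(/C=C/CC(C)CCCC(C)C)=C\C(=O)O`: 5.95
Compound 3 `CCC(C)OC(=O)/C=C(C)/C=C/CC(C)CCCC(C)(C)OC`: 6.49

Of the compounds shown here, three have been measured in a physicochemical assay for lipophilicity; a lower number here means a more polar compound, a higher number a more lipophilic compound. Compound 1 gives the highest number, 7.69. Compound 2 gives the lowest, 5.95. Compound 3 stands between them with 6.49, nearer to compound 2 than to compound 1. Two steps are known: a number 1.74 log units lower from compound 1 to compound 2 (beyond the scatter), and a number 1.20 log units lower from compound 1 to compound 3 (beyond the scatter). Both were large and both went down.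

Compound 4 `C=CCSC(=O)/C=C(C)/C=C/CC(C)CCCC(C)(C)OC` has not yet been measured in this assay. It differs from compound 3 in one place: allylsulfanyl in place of sec-butoxy on a carbonyl carbon. Neither measured step bears directly on this change. The step from compound 1 to compound 2 removed the sec-butyl from the ester oxygen altogether, leaving an acid, whereas here a sec-butoxy is exchanged for an allylsulfanyl while the carbonyl is kept. The step from compound 1 to compound 3 concerns the methoxy, which is unchanged between compound 3 and compound 4. Among the measured compounds shown here, with no direct precedent, the expected step of a number 0.11 log units higher from compound 3 to compound 4 (within the scatter) is small, most likely within the scatter, with a slight lean upward. Compound 4 is therefore estimated at 6.6 in this assay, in the range 6 to 7.2.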

Compound 4, partition coefficient: 6.77
Compound 4: the middle estimate sits 0.17 log units below what was measured; measured number inside the range.
By their numbers in this assay, from the lowest: compound 2; then compounds 3 and 4 (each within the scatter of the next); then compound 1.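

In this assay, replacing sec-butoxy with allylsulfanyl on a carbonyl carbon gives a number 0.28 log units higher from compound 3 to compound 4 (within the scatter) and so cannot be told apart from the scatter of the measurement. This is the only step shown at this position that keeps the carbonyl and places another group on it, and it contrasts with a number 1.74 log units lower from compound 1 to compound 2 (beyond the scatter) on the chain without the methoxy, where removing the sec-butyl left an acid. Compounds 3 and 4 thus show that, on the chain bearing the methoxy, this position can carry either sec-butoxy or allylsulfanyl without a step beyond the scatter, although no information offered here accounts for this result.

The exchange alters the atom on the carbonyl carbon and the chain beyond it in a single step, leaving open what allyloxy or sec-butylsulfanyl would show for each part alone. Also open, from the compounds shown here alone, are whether the same exchange behaves alike on the chain without the methoxy, as in compound 1, and how an amide or a longer chain on the sulfur would read in this assay at this position.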